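The compounds below may be only part of what the source reports. "The series", "measured", "known", "first", "only" and "open" are said of these compounds alone.

Within the data shown here, compound 1 `CC(C)[C@H](NC(=O)COc1cccc2ccccc12)C(=O)N[C@@H](CC(=O)O)C(=O)COc1ccc(-c2ccccc2)cc1` is the only member of the series with a number rather than a limit: in a functional assay on Jurkat cells (Homo sapiens) (a lower number here means a stronger inhibitor, a higher number a weaker inhibitor), compound 1 gives 87900 nM. Compound 2 `CC(C)[C@H](NC(=O)COc1cccc2ccccc12)C(=O)N[C@@H](CC(=O)O)C(=O)COc1cccc(F)c1` reaches only the limit of the assay, > 100000 nM in this assay. Compound 3 `CC(C)[C@H](NC(=O)COc1cccc2ccccc12)C(=O)N[C@@H](CC(=O)O)C(=O)COc1ccc(F)cc1` likewise stops at the limit, > 100000 nM. The steps read an at least 1.1-fold higher number from compound 1 to compound 2 (0.05 log units; that floor lies within the scatter) and an at least 1.1-fold higher number from compound 1 to compound 3 (0.05 log units; that floor lies within the scatter); between the two fluorophenyl compounds the step is a step that the two limits leave unreadable from compound 2 to compound 3, since the limit of > 100000 nM in this assay, at which 2 of the 3 values shown sit, caps both. On these data alone, compound 4 `CC(C)[C@H](NC(=O)COc1cccc2ccccc12)C(=O)N[C@@H](CC(=O)O)C(=O)COc1ccc(F)c(F)c1` is untested; against compound 1 the change is 3,4-difluorophenyl in place of 4-phenylphenyl on an oxygen on a saturated carbon. Both measured steps away from the 4-phenylphenyl of compound 1 onto a fluorophenyl end at the limit, and the 3,4-difluorophenyl of compound 4 keeps fluorine on the phenyl as in compound 2 and compound 3. The expected step is therefore a 1.7-fold higher number from compound 1 to compound 4 (0.23 log units; within the scatter), toward a weaker inhibitor, most probably ending at the limit once more. Compound 4 is estimated at 150000 nM in this assay, within 80000 nM to 400000 nM.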

Compound 4, half-maximal inhibitory concentration: > 100000 nM
Compound 4 ended at the assay's limit; the forecaster's own chance of this, stated with the estimate: 75%; the middle value is on the limit's open side.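

In this assay, a second fluorine on the phenyl does not lift compound 4 off the ceiling, which is a limit and not a number; the steps from compound 2 and compound 3 to compound 4 cannot be read. Replacing the 4-phenylphenyl with 3,4-difluorophenyl gives an at least 1.1-fold higher number from compound 1 to compound 4 (0.05 log units; that floor lies within the scatter), so only a floor is known for this change, and it does not establish a real loss. All three fluorophenyl compounds now end at the same ceiling, leaving compound 1 as the only one with a number: the limit of > 100000 nM in this assay, at which 3 of the 4 values shown sit.

On these data alone, whether any fluorophenyl compound truly differs from compound 1, or from another fluorophenyl compound, remains open. Also open, as far as these compounds go, is how a pyridine ring or a benzyl group on that oxygen would read.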